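The source may report more compounds than this note shows. Statements on the series, on what has been measured and on what is new or still open speak of the compounds shown alone.

Three compounds built around a pair of linked aromatic heterocycles have been tested in a functional assay on U-937 cells (Homo sapiens) for cytotoxicity, read by MTT assay, with a stated time of 48 h (on this read-out lower numbers stand for stronger inhibition and higher numbers for weaker inhibition), and a fourth awaits its result.

Compound 1 `S=C(Nc1ccc(Cl)cc1)Nc1nc2ccccc2s1` gives only a limit in this assay, > 50000 nM. Compound 2 `Fc1ccc(NC(=S)Nc2nc3ccccc3s2)cc1` gives 32100 nM in this assay. The two differ by fluoro in place of chloro on an aromatic carbon, and the step is an at least 1.5-fold lower number from compound 1 to compound 2 (0.19 log units; that floor lies within the scatter), its floor set by the limit of > 50000 nM in this assay, at which 2 of the 3 values shown sit.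

Compound 3 `Fc1ccc2nc(Nc3nc4ccc(Cl)cc4s3)sc2c1` also gives only a limit in this assay, > 50000 nM. The difference between the core of compound 3 and the core of compound 1 is not broken down here.

Compound 4 `Fc1ccc2nc(Nc3nc4ccc(F)cc4s3)sc2c1` has not yet been measured. It differs from compound 3 by fluoro in place of chloro on an aromatic carbon. Within the data shown here, this is the same kind of change as the one from compound 1 to compound 2, though the surroundings differ: in compound 2 the fluoro sits para to a large group, whereas in compound 4 it sits meta to a fused ring and para to a fused ring, on a ring that is part of a fused or bridged system of two rings.

Given that compound 3 sits at the limit > 50000 nM and that the earlier swap produced only an at least 1.5-fold lower number from compound 1 to compound 2 (0.19 log units; that floor lies within the scatter), a small step of an at least 1.1-fold lower number from compound 3 to compound 4 (0.04 log units; that floor lies within the scatter) is expected. Compound 4 is therefore estimated at 45000 nM in this assay, between 15000 nM and 120000 nM.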

Compound 4, half-maximal inhibitory concentration: 27400 nM
Estimate against measurement, compound 4: 1.6-fold (0.22 log units) above; measured number inside the range.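

The same swap has now been seen on two cores in this assay, and on the second it gives an at least 1.8-fold lower number from compound 3 to compound 4 (0.26 log units; that floor lies within the scatter); on both cores the fluoro compound has a measured number and the chloro compound does not, which is as far as the comparison goes: the same change on two cores in this assay, an at least 1.5-fold lower number (0.19 log units; that floor lies within the scatter) from compound 1 to compound 2 and an at least 1.8-fold lower number (0.26 log units; that floor lies within the scatter) from compound 3 to compound 4; the limit leaves it open whether they differ Neither step has a true size, only a floor, because the chloro compounds, compound 1 and compound 3, both sit at a limit of the assay rather than at a number: the limit of > 50000 nM in this assay, at which 2 of the 4 values shown sit. This does not show that the swap has the same effect on the two cores, or that it has any effect beyond the usual scatter on either of them.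

The compounds shown carry only chloro or fluoro at the changed carbon, so what an amine, a methoxy group or a carboxylic acid would do there remains open. Also open is how the two cores compare, as no pair shown differs by the core alone.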